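The source may report more compounds than this note shows. Statements on the series, on what has been measured and on what is new or still open speak of the compounds shown alone.

In a functional assay on HCT-116 cells (Homo sapiens) for antiproliferative activity, read by sulforhodamine B assay, with a stated time of 72 h (a higher number here means a weaker inhibitor, a lower number a stronger inhibitor), compound 1 (`COc1ncc(-c2ccc3ncc(NCc4ccc(C(F)(F)F)cc4)c(OC)c3c2)cc1NS(=O)(=O)c1ccc(F)cc1F`) gives 3220 nM and compound 2 (`COc1ncc(-c2ccc3ncc(NC(=O)C4CCCCC4)c(OC)c3c2)cc1NS(=O)(=O)c1ccc(F)cc1F`) gives 4610 nM, with a 1.4-fold higher number from compound 1 to compound 2 (0.16 log units; within the scatter). Compound 3 (`COc1ccc(CNc2cnc3ccc(-c4cnc(OC)c(NS(=O)(=O)c5ccc(F)cc5F)c4)cc3c2OC)cc1`) stands highest of the three at 10200 nM, with a 3.2-fold higher number from compound 1 to compound 3 (0.50 log units; beyond the scatter). Compound 4 (`COc1ncc(-c2ccc3ncc(NC(=O)CN4CCCC(O)C4)c(OC)c3c2)cc1NS(=O)(=O)c1ccc(F)cc1F`) carries ((3-hydroxypiperidin-1-yl)methyl)carbonyl in place of 4-methoxybenzyl on a nitrogen on an aromatic ring. The closest measured comparison is compound 2, which carries cyclohexylcarbonyl at that nitrogen, with a 2.2-fold higher number from compound 2 to compound 3 (0.34 log units; beyond the scatter). Going by the values given here, a modest step to a lower number in this assay is therefore expected, although no measured compound carries the entering group. The expected step is a 2.6-fold lower number from compound 3 to compound 4 (0.41 log units; beyond the scatter). For compound 4 the estimate is 4000 nM, with an expected range of 1000 nM to 15000 nM.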

Compound 4, half-maximal inhibitory concentration: 1770 nM
Compound 4: the middle estimate sits 2.3-fold (0.35 log units) above what was measured; low and high end bracket the measured number.
By their numbers in this assay, from the lowest: compounds 4, 1 and 2 (each within the scatter of the next, the first and the last beyond it); then compound 3.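

In (this assay), a ring bearing a hetero atom is accepted on this nitrogen: ((3-hydroxypiperidin-1-yl)methyl)carbonyl in place of 4-methoxybenzyl gives (a 5.8-fold lower number from compound 3 to compound 4 (0.76 log units; beyond the scatter)), and (3-hydroxypiperidin-1-yl)methyl in place of cyclohexyl on the carbonyl carbon gives (a 2.6-fold lower number from compound 2 to compound 4 (0.42 log units; beyond the scatter)). Against 4-(trifluoromethyl)benzyl the change stays within the scatter (a 1.8-fold lower number from compound 1 to compound 4 (0.26 log units; within the scatter)), so the gain is not general across the groups shown. No measurement on hand explains these steps. On these data alone, it remains open whether the hydroxyl matters, and how an unsubstituted piperidine, a morpholine or a carboxylic acid would behave on the same methylcarbonyl link.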